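The source may report more compounds than this note shows. Statements on the series, on what has been measured and on what is new or still open speak of the compounds shown alone.

Working notes on a chalcone-type series built on a shared core bearing a methylamide-substituted pyridine ether.

Among the compounds with values here, compound 1 `CNC(=O)c1cc(Oc2ccc(C(=O)/C=C/c3ccc(Cl)cc3Cl)cc2)ccn1` is the only member with a number in hand. Within the data shown here, in a functional assay on A549 cells (Homo sapiens) for cytotoxicity, read by MTT assay, with a stated time of 72 h (a higher number here means a weaker inhibitor, a lower number a stronger inhibitor), compound 1 gives 9460 nM, so it is a weak inhibitor on the single value available; it stands alone, with no second number to rank it against. Compound 2 `CNC(=O)c1cc(Oc2ccc(C(=O)/C=C/c3ccc(OC)c(OC)c3OC)cc2)ccn1` carries three methoxy groups on the aryl end of the chain; in this assay compound 2 is recorded only as "not determined" (no result reported), so it gives no number for comparison.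

Compound 3 `CNC(=O)c1cc(Oc2ccc(C(=O)/C=C/c3ccc(Cl)c(Cl)c3)cc2)ccn1` is the closest relative of compound 1. The change is 3,4-dichlorophenyl in place of 2,4-dichlorophenyl on a double-bonded chain carbon bound to a double-bonded chain carbon. Among the measured compounds shown here, nothing measured tells how moving the chlorines about the ring affects the read-out, and no step between measured pairs exists. The expectation is therefore a step of a 1.1-fold lower number from compound 1 to compound 3 (0.05 log units; within the scatter) from compound 1 to compound 3, which is within the usual scatter rather than a real shift in either direction. For compound 3 in this assay the estimate is 8500 nM, with a plausible range from 3000 nM to 25000 nM.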

Compound 3, half-maximal inhibitory concentration: 33700 nM
Compound 3: middle estimate off by 4.0-fold (0.60 log units), on the low side, outside the stated range (above it).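

Within the data shown here, the first readable step shows that the arrangement of the two chlorines on the aryl end of the chain matters: 3,4-dichlorophenyl in place of 2,4-dichlorophenyl gives a 3.6-fold higher number from compound 1 to compound 3 (0.55 log units; beyond the scatter) in this assay and moves toward a weaker inhibitor, beyond the scatter though modest in size. The leaving and entering groups have the same atoms and the same counted features, so at this place on the chain the read-out responds to a rearrangement alone, and of these two compounds the one bearing 2,4-dichlorophenyl is the stronger. No measurement at hand explains the difference between the two arrangements.

Steps to compound 2 cannot be read, so the series gives no comparison between the trimethoxyphenyl end and either dichlorophenyl end. Also open, as far as these compounds go, is whether any chlorine is needed on the aryl end at all, as a single chlorine, a fluorine or an unsubstituted phenyl would show, and whether the methylamide on the shared core can give way to a carboxylic acid or a dimethylamide.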